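This account rests on a few compounds, and the source may have more. Where it says the series, first, only, none or still open, it means among the compounds named here.

Three compounds were measured in an ADME assay on Huh-7 cells (Homo sapiens) for cytotoxicity, read by MTT assay, with a stated time of 72 h; on this read-out higher numbers stand for lower toxicity in this test and lower numbers for higher toxicity in this test:

Compound 1 `Cc1cc(=O)oc2cc(OCc3cn(-c4ccc(F)cc4F)nn3)ccc12` gives only the assay limit > 100 ug/mL in this assay.
Compound 2 `Cc1cc(F)ccc1-n1cc(COc2ccc3c(C)cc(=O)oc3c2)nn1` gives only the assay limit > 100 ug/mL in this assay.
Compound 3 `Cc1ccc(-n2cc(COc3ccc4c(C)cc(=O)oc4c3)nn2)c(Cl)c1` gives only the assay limit > 100 ug/mL in this assay.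

For the measured compounds named here, compound 3 therefore stands at the limit of > 100 ug/mL in this assay, at which 3 of the 3 values shown sit, and no measured compound separates from it. The steps a step that the two limits leave unreadable from compound 1 to compound 2, a step that the two limits leave unreadable from compound 1 to compound 3 and a step that the two limits leave unreadable from compound 2 to compound 3 all change the group on the aromatic nitrogen without yielding a readable size. Compound 4 `COC(=O)Cn1cc(COc2ccc3c(C)cc(=O)oc3c2)nn1` follows the same pattern of change: (methoxycarbonyl)methyl in place of 2-chloro-4-methylphenyl on an aromatic nitrogen. Because every measured step to this position sits at the limit of > 100 ug/mL in this assay, at which 3 of the 3 values shown sit, no change beyond the scatter is expected, and the step of a number no higher from compound 3 to compound 4 (the limit leaves the size open) is expected to stay unreadable. Compound 4 is estimated at 100 ug/mL, within 50 ug/mL to 200 ug/mL, most likely again as a limit.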

Compound 4, half-maximal cytotoxic concentration: > 100 ug/mL
Compound 4 gave a limit, no number (the forecaster's own chance of this, stated with the estimate: 85%); the middle value lies on the limit itself.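

Compound 4 gives only a limit, as do compound 1, compound 2 and compound 3, so none of its steps from those three can be read: the limit of > 100 ug/mL in this assay, at which 4 of the 4 values shown sit.

Going by these compounds, whether the group on the aromatic nitrogen changes the result in this assay stays open.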